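Replacing a branched chain with an acetylcyclohexylmethyl group

A few compounds are considered here, and "the series" means these few. Any claim that something is new, unique, unknown or untested is made for them only; others in the source may bear on it.

Measured compounds:
compound 1 `CCCC(CCC)n1c(-c2ccc(OCc3c(-c4c(Cl)cccc4Cl)noc3C(C)C)cc2)nc2ccc(C(=O)O)cc21`: > 10000 nM
compound 2 `CC(C)c1onc(-c2c(Cl)cccc2Cl)c1COc1ccc(-c2nc3ccc(C(=O)O)cc3n2CC2CCCCC2)c(Cl)c1`: 160 nM

Compound 1 was tested in an assay on HEK-293T cells for antagonist activity at vitamin D3 receptor (Homo sapiens), read by a luciferase reporter, with a stated time of 24 h (on this read-out higher numbers stand for weaker inhibition and lower numbers for stronger inhibition), and its result, > 10000 nM, is a limit of the assay rather than a number (the limit of > 10000 nM in this assay, at which 1 of the 2 values shown sits). Compound 2 gives 160 nM in this assay. Compound 3 `CC(=O)C1CCC(Cn2c(-c3ccc(OCc4c(-c5c(Cl)cccc5Cl)noc4C(C)C)cc3)nc3ccc(C(=O)O)cc32)CC1` arises from compound 1 by a single change: (4-acetylcyclohexyl)methyl in place of 1-propylbutyl on an aromatic nitrogen. In this assay a shift toward stronger inhibition is expected, though with compound 1 at a limit its size is uncertain. Compound 3 is estimated at 2000 nM, with a range from 300 nM to 10000 nM. The expected step is an at least 5.0-fold lower number from compound 1 to compound 3 (0.69 log units; beyond the scatter).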

Compound 3, half-maximal inhibitory concentration: > 10000 nM
Compound 3 gave a limit, no number; the forecaster's own chance of this, stated with the estimate: 35%; at least 5.0-fold (0.69 log units) between middle value and limit.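

No step can be read from compound 1 to compound 3, because each result is a limit rather than a number: the limit of > 10000 nM in this assay, at which 2 of the 3 values shown sit. From the compounds shown here alone, whether (4-acetylcyclohexyl)methyl in place of 1-propylbutyl changes inhibition at all remains open.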